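A few compounds are considered here, and "the series" means these few. Any claim that something is new, unique, unknown or untested is made for them only; others in the source may bear on it.

Of the compounds shown here, three have so far been measured in a functional assay for agonist activity at G protein-coupled receptor 88 (Homo sapiens), read by HTRF and cAMP accumulation; a lower number here means that less compound is needed, a higher number that more compound is needed for the effect. Compound 1 `CC(C)(N)CN(C(=O)[C@@H]1C[C@H]1c1ccccc1)c1ccc(-c2ccccc2)cc1` gives 1.4 nM, compound 2 `CC[C@H](C)[C@H](N)CN(C(=O)[C@@H]1C[C@H]1c1ncccn1)c1ccc(-c2ccccc2)cc1` gives 130 nM, and compound 3 `CC[C@H](C)[C@H](N)CN(C(=O)[C@@H]1C[C@H]1c1ccccc1)c1ccc(-c2ccc(C(C)(C)C)cc2)cc1` gives 750 nM, the highest of the three numbers and beyond the scatter from both of the others. Compound 3 differs from each of them in more than one place, so no single change can be read off for its position. Compound 4 `CC[C@H](C)[C@H](N)CN(C(=O)[C@@H]1C[C@H]1c1ccccc1)c1ccc(-c2ccc(CCC(=O)OC)cc2)cc1` carries one change from compound 3: 2-(methoxycarbonyl)ethyl in place of tert-butyl on an aromatic carbon. Within the data shown here, no measured pair shows what such a swap does here, so the expected step of a 1.7-fold lower number from compound 3 to compound 4 (0.22 log units; within the scatter) is modest, with either direction possible. Compound 4 is expected to give about 450 nM, within 100 nM to 2000 nM.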

Compound 4, half-maximal effective concentration: 110 nM
The estimate for compound 4 lay 4.1-fold (0.61 log units) above the measured number; low and high end bracket the measured number.
By their numbers in this assay, from the lowest: compound 1; then compounds 4 and 2 (each within the scatter of the next); then compound 3.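

In this assay the replacement of tert-butyl by 2-(methoxycarbonyl)ethyl gives a 6.8-fold lower number from compound 3 to compound 4 (0.83 log units; beyond the scatter) and so shows, beyond the scatter, that the number responds to what sits on this aromatic carbon, para to a large group. The larger group with its two hydrogen-bond acceptors is accepted here with the lower number. No evidence at hand explains the step.

Going by these compounds, it remains open whether the chain alone or its oxygens matter. A plain propyl group or a carboxylic acid at this place would be the direct comparisons.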